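Trifluoromethyl on the inactive parent of the series

A few compounds are considered here, and "the series" means these few. Any claim that something is new, unique, unknown or untested is made for them only; others in the source may bear on it.

Measured so far:
compound 1 `Cc1cc(O)c(C(=O)/C=C/c2ccccc2)c(=O)o1` gives > 100000 nM (a limit)
compound 2 `COc1ccc(/C=C/C(=O)c2c(O)cc(C)oc2=O)cc1` gives > 100000 nM (a limit)

In a functional assay on HCT-116 cells (Homo sapiens) for cytotoxicity, read by MTT assay (a higher number here means a weaker inhibitor, a lower number a stronger inhibitor), compound 1 gives > 100000 nM as a limit and not a number. Among the compounds with values here, its true position is therefore unknown, and the only other compound offers no number either. Compound 2 gives > 100000 nM as a limit too. The evidence so far is the limit of > 100000 nM in this assay, at which 2 of the 2 values shown sit, and nothing more.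

Compound 3 `Cc1cc(O)c(C(=O)/C=C/c2ccccc2C(F)(F)F)c(=O)o1` differs from compound 1 by trifluoromethyl in place of hydrogen on an aromatic carbon and is ortho to a large group.

Within the data shown here, the one measured step that bears on this is a step that the two limits leave unreadable from compound 1 to compound 2 and it has no readable size. It also concerns methoxy rather than trifluoromethyl, so it gives only weak guidance. Among the measured compounds shown here, no step in a known direction is therefore expected in this assay and compound 3 will most likely stay at the limit, with a modest chance of a readable number.

The estimated step is a number no higher from compound 1 to compound 3 (the limit leaves the size open) and it is expected to be poorly defined. For compound 3 the expected value is 100000 nM with an estimated range from 30000 nM to 200000 nM for now.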

Compound 3, half-maximal inhibitory concentration: > 100000 nM
Compound 3: only a limit was reported (the forecaster's own chance of this, stated with the estimate: 70%); the middle value lies on the limit itself.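

Compound 1 and compound 3 both give only a limit in this assay, so no size can be read for trifluoromethyl in place of hydrogen on an aromatic carbon: the limit of > 100000 nM in this assay, at which 3 of the 3 values shown sit.

The compounds shown leave open whether any change on the shared core gives a readable number in this assay.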